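The source may hold more compounds than are shown below. What is called first, only, known or untested is meant among the compounds shown, and "the series" means these compounds.

Compound 1 `O[C@H](COCCOC[C@@H](O)Cc1cn(Cc2ccc3ccccc3c2)nn1)Cc1ccc(-c2ccccc2)cc1` carries a (naphthalen-2-yl)methyl group on the aromatic nitrogen of the shared core. In a functional assay on HCT-116 cells (Homo sapiens) for inhibition, read by MTT assay, with a stated time of 72 h (a lower number here means a stronger inhibitor of growth, a higher number a weaker inhibitor of growth), compound 1 gives 8600 nM, the highest of the two numbers recorded; compound 2 `O[C@H](COCCOC[C@@H](O)Cc1cn(Cc2ccc(Oc3ccccc3)cc2)nn1)Cc1ccc(-c2ccccc2)cc1`, with a 4-phenoxybenzyl group in that place, gives 3400 nM. Compound 3 `O[C@H](COCCOC[C@@H](O)Cc1c[nH]nn1)Cc1ccc(-c2ccccc2)cc1`, bearing only hydrogen on that nitrogen, reaches no number in this assay but only a limit, > 100000 nM. The step of an at least 11-fold higher number from compound 1 to compound 3 (1.06 log units; beyond the scatter) therefore shows how much the aromatic group contributes, with the limit of > 100000 nM in this assay, at which 1 of the 3 values shown sits, marking the edge of what could be measured.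

Compound 4 `N#Cc1ccc(Cn2cc(C[C@H](O)COCCOC[C@@H](O)Cc3ccc(-c4ccccc4)cc3)nn2)cc1` is not yet measured. It differs from compound 1 by 4-cyanophenyl in place of naphthalen-2-yl on a saturated chain carbon bound to an aromatic nitrogen: a 4-cyanobenzyl group replaces the (naphthalen-2-yl)methyl group, so one six-membered aromatic ring of carbon only is lost and a triple bond outside aromatic rings enters. The large step from compound 1 to compound 3 is the only one that bears on this, and it concerns full removal rather than a smaller aromatic ring, so a weaker but real loss is expected. Compound 4 is estimated at 20000 nM, between 7000 nM and 60000 nM, which means an expected step of a 2.3-fold higher number from compound 1 to compound 4 (0.37 log units; beyond the scatter).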

Compound 4, concentration for 50% growth inhibition: 8800 nM
Compound 4: middle estimate off by 2.3-fold (0.36 log units), on the high side; low and high end bracket the measured number.
By their numbers in this assay, from the lowest: compound 2; then compounds 1 and 4 (each within the scatter of the next). At a limit, above all of these: compound 3.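

In this assay, the step of a 1.0-fold higher number from compound 1 to compound 4 (0.01 log units; within the scatter) lies within the scatter, so on a saturated chain carbon bound to an aromatic nitrogen, 4-cyanophenyl with its one six-membered aromatic ring of carbon only holds the number given by naphthalen-2-yl with two such rings. The step of an at least 11-fold lower number from compound 3 to compound 4 (1.05 log units; beyond the scatter) shows with a second group that a substituent on the aromatic nitrogen matters, although it is read against a limit of the assay: the limit of > 100000 nM in this assay, at which 1 of the 4 values shown sits. The choice of group still shows, as the step of a 2.6-fold higher number from compound 2 to compound 4 (0.41 log units; beyond the scatter) for cyano in place of phenoxy lies beyond the scatter.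

Going by these compounds, whether an amine or a carboxylic acid in place of the cyano group would keep this number remains open. So does the outcome for plain benzyl, or for a longer chain in place of the single chain carbon.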